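A few compounds are considered here, and "the series" means these few. Any claim that something is new, unique, unknown or untested is made for them only; others in the source may bear on it.

Measured in a functional assay on the whole organism with Rattus norvegicus as the target; a lower number here means that less compound is needed, a higher number that more compound is needed for the effect:
- compound 1 `CC(C#CC[N+](C)(C)C)OC(=O)Nc1cccc(Cl)c1`: 0.09 umol/kg
- compound 2 `C[C@@H](C#CC[N+](C)(C)C)OC(=O)Nc1cccc(Cl)c1`: 0.12 umol/kg

Compound 2, at 0.12 umol/kg, cannot be told apart from compound 1 in this assay. Compound 3 `C[C@H](C#CC[N+](C)(C)C)OC(=O)Nc1cccc(Cl)c1` is still unmeasured and follows from compound 2 by a single change: the two compounds have the same atoms and bonds and differ only in configuration as drawn: 1 of 1 stereo elements differ; a stereocentre at a saturated chain carbon is drawn S in compound 2 and R in compound 3. No group leaves or enters.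

Among the measured compounds shown here, only one measured step bears on this change: a 1.3-fold higher number from compound 1 to compound 2 (0.12 log units; within the scatter). This step lies within the scatter, and the sole structural difference behind it is the fact that one of compounds 1 and 2 is drawn with a defined configuration and the other without, at the place where they differ. It does not measure the R configuration directly. The reading is indirect and holds only if compound 1 contains both configurations, which the data do not state. In that case, the mixture at 0.09 umol/kg for compound 1 would argue against an R form needing far more compound than the S form.

The expected outcome is no change beyond the scatter, and a 1.3-fold higher number from compound 2 to compound 3 (0.10 log units; within the scatter) is the estimated step. The range is kept wider towards higher numbers. Compound 3 is estimated at 0.15 umol/kg, with an expected range of 0.04 umol/kg to 1 umol/kg.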

Compound 3, dose for half-maximal effect: 0.18 umol/kg
For compound 3 the middle estimate is 1.2-fold (0.08 log units) below the measured one, within the range that was stated.
By their numbers in this assay, from the lowest: compounds 1, 2 and 3 (each within the scatter of the next).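

Among the compounds shown here, the S and R forms can now be compared directly, where the earlier compounds allowed only an indirect reading through compound 1, whose composition is not stated. In this assay the step is a 1.5-fold higher number from compound 2 to compound 3 (0.18 log units; within the scatter), and the only structural difference behind it is this: the fact that compounds 2 and 3 differ only in the configuration as drawn. The comparison with the compound drawn without a configuration gives a 2.0-fold higher number from compound 1 to compound 3 (0.30 log units; within the scatter), so all three compounds lie within the scatter of one another, and at this stereocentre the assay does not separate the drawn configurations.

It remains open whether this lack of separation would persist with an ethyl group or a longer chain at the stereocentre, since the compounds shown vary only the configuration and not the substituent on that carbon. Whether compound 1 contains both configurations, and in what proportion, also remains unstated, so its value cannot be read as that of a defined mixture.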